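Aryl sulfonate anilides: amide to urea at compound 2

A few compounds are considered here, and "the series" means these few. Any claim that something is new, unique, unknown or untested is made for them only; others in the source may bear on it.

Measured so far in a functional assay on HT-29 cells (Homo sapiens) for antiproliferative activity, read by sulforhodamine B assay, with a stated time of 48 h; a higher number here means a weaker inhibitor, a lower number a stronger inhibitor:
- compound 1 `CCCCCC(=O)Nc1cccc(S(=O)(=O)Oc2ccccc2C(C)C)c1` gives 19000 nM
- compound 2 `CCCC(=O)Nc1ccc(S(=O)(=O)Oc2ccccc2C(C)C)cc1` gives 4900 nM
- compound 3 `CCCC(=O)Nc1ccc(S(=O)(=O)Oc2ccccc2I)cc1` gives 11000 nM

Compound 2 holds the lowest of the three numbers; compound 3 sits nearest to it and compound 1 furthest, both beyond the scatter. Within the data shown here, the only single-place step in the set, a 2.2-fold higher number from compound 2 to compound 3 (0.35 log units; beyond the scatter), concerns iodo in place of isopropyl on an aromatic carbon and says nothing about the carbonyl side of the molecule.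

Compound 4 `CC(C)c1ccccc1OS(=O)(=O)c1ccc(NC(=O)NC2CCCC2)cc1` differs from compound 2 by cyclopentylamino in place of propyl on a carbonyl carbon. Among the measured compounds shown here, no measured pair tests a change of this kind, so no direction can be read from the series. The estimate for compound 4 is therefore 5000 nM, with a range of 1500 nM to 16000 nM. The implied step, a 1.0-fold higher number from compound 2 to compound 4 (0.01 log units; within the scatter), is expected to stay within the usual scatter.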

Compound 4, half-maximal inhibitory concentration: 7400 nM
The estimate for compound 4 lay 1.5-fold (0.17 log units) below the measured number; measured number inside the range.
By their numbers in this assay, from the lowest: compounds 2, 4, 3 and 1 (each within the scatter of the next, the first and the last beyond it).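

Among these compounds, the step, a 1.5-fold higher number from compound 2 to compound 4 (0.18 log units; within the scatter), gives the first reading on the carbonyl side of the molecule. Cyclopentylamino in place of propyl on a carbonyl carbon brings in a five-membered ring and a hydrogen-bond donor, yet the number for compound 4 cannot be told apart from that of compound 2.

Still open, from the compounds shown here alone, is whether an open chain such as pentylamino, a smaller methylamino or a phenylamino group would fit this place equally well, and whether the same change holds alongside the iodo group of compound 3. No supporting evidence bears on why the two numbers lie so close.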